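The compounds below may be only part of what the source reports. "The series", "measured", "known", "first", "only" and "open" are said of these compounds alone.

Measured compounds:

Compound 1, `Nc1ccc2cccc(OC3CCC3)c2n1`. In an assay on cells with melanin-concentrating hormone receptor 1 (Homo sapiens) as the target, read by radioligand binding (a higher number here means a weaker inhibitor, a lower number a stronger inhibitor), compound 1 gives > 2000 nM, which is a limit of the assay and not a number.
Compound 2, `CC#CCCOc1cccc2ccc(N)nc12`. In this assay compound 2 gives > 2000 nM, again a limit rather than a number.
Compound 3, `CC(CC(C)(C)C)Oc1cccc2ccc(N3CCCC3)nc12`. In this assay compound 3 gives > 2000 nM, also a limit.

Compound 2 therefore stands only at a limit, as do the other two values shown; the whole set sits on (the limit of > 2000 nM in this assay, at which 3 of the 3 values shown sit). For the measured compounds named here, the one step between measured compounds that differ in one place, a step that the two limits leave unreadable from compound 1 to compound 2, is unreadable for that reason.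

The unmeasured compound 4 is `Nc1ccc2cccc(OCC3CCOC3)c2n1`. It differs from compound 2 as oxolan-3-yl in place of but-2-yn-1-yl on a saturated chain carbon bound to an oxygen on an aromatic ring. Going by the values given here, no measured step bears on this change: the step from compound 1 to compound 2 shows only that two limits were reached, and compound 3 adds a third limit with no readable difference to either. Nothing in the data suggests that compound 4 moves off the limit, so a step of no readable size is expected, a step that the limit leaves unreadable from compound 2 to compound 4, and compound 4 is estimated at 4000 nM, between 1500 nM and 20000 nM.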

Compound 4, half-maximal inhibitory concentration: 115 nM
Estimate against measurement, compound 4: 35-fold (1.54 log units) above; measured number outside the range, below it.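

In this assay the group on the oxygen on an aromatic ring can carry the series off the limit: oxolan-3-yl in place of but-2-yn-1-yl gives an at least 17-fold lower number from compound 2 to compound 4 (1.24 log units; beyond the scatter), and (oxolan-3-yl)methyl in place of cyclobutyl gives an at least 17-fold lower number from compound 1 to compound 4 (1.24 log units; beyond the scatter). The core of compound 1 is therefore able to give a readable number, and the group on that oxygen decides whether it does. The true size of both steps stays unknown because compound 1 and compound 2 each sit at a limit: the limit of > 2000 nM in this assay, at which 3 of the 4 values shown sit.

Which part of (oxolan-3-yl)methyl carries the change stays open, and a cyclopentylmethyl group would separate the ring oxygen from the ring itself. As far as these compounds go, how a larger ring such as (oxan-4-yl)methyl would read in this assay is also open.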